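Benzyl-Acetyl Amide in Place of a Phenylurea

This account rests on a few compounds, and the source may have more. Where it says the series, first, only, none or still open, it means among the compounds named here.

Measured so far:
Compound 1 `CCCCc1ccc(CN(Cc2ccccc2)S(=O)(=O)c2ccccc2)c(=O)n1Cc1ccc(-c2ccccc2-c2nn[nH]n2)cc1` gives 75.7% in a functional assay on the whole organism (artery) for inhibition, with Rattus norvegicus as the target, at a dose of 3 mg/kg by the intraduodenal route; a higher number here means more inhibition at the dose given (going by the name of the read-out), a lower number less inhibition.
Compound 2 `CCCCc1ccc(CN)c(=O)n1Cc1ccc(-c2ccccc2-c2nn[nH]n2)cc1` gives 2.8% in this assay.
Compound 3 `CCCCc1ccc(CNC(=O)Nc2ccccc2)c(=O)n1Cc1ccc(-c2ccccc2-c2nn[nH]n2)cc1` gives 0% in this assay.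

Compound 3 stands lowest of the three numbers. Its nearest neighbour is compound 2, and the step of a number 2.8 percentage points lower from compound 2 to compound 3 (within the scatter) lies within the scatter, so the two cannot be ordered. Compound 1 stands far above both, beyond the scatter.

Compound 4 is `CCCCc1ccc(CN(Cc2ccccc2)C(C)=O)c(=O)n1Cc1ccc(-c2ccccc2-c2nn[nH]n2)cc1`. It differs from compound 3 by acetyl(benzyl)amino in place of (phenylcarbamoyl)amino on a saturated chain carbon bound to an aromatic carbon. Among the compounds with values here, the only measured step, a number 2.8 percentage points lower from compound 2 to compound 3 (within the scatter), concerns the phenylcarbamoyl on a free amine and says little about the present change. What bears on it more is the comparison of compound 1 with compound 2: the nitrogen carrying both a benzyl and a benzenesulfonyl group gives a high number, the free amine a number near zero. Compound 4 likewise carries a benzyl together with an acetyl on that nitrogen. Within the data shown here, on that basis a large rise is expected, a number 45 percentage points higher from compound 3 to compound 4 (beyond the scatter), though with wide uncertainty since no acetyl analogue has been measured.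

Compound 4 is therefore estimated at 45%, with a range from 10% to 80% in this assay.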

Compound 4, a percentage reported as inhibition, in the whole organism at one dose (the size of the read-out at that dose, not a potency): 76.3%
Compound 4: middle estimate off by 31.3 percentage points, on the low side; the range from low to high includes it.
By their numbers in this assay, from the lowest: compounds 3 and 2 (each within the scatter of the next); then compounds 1 and 4 (each within the scatter of the next).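

In this assay the swap of (phenylcarbamoyl)amino for acetyl(benzyl)amino on the saturated chain carbon gives a number 76.3 percentage points higher from compound 3 to compound 4 (beyond the scatter), and the swap of amino for acetyl(benzyl)amino gives a number 73.5 percentage points higher from compound 2 to compound 4 (beyond the scatter), so a high number at this place does not come from simply having a six-membered aromatic ring of carbon only in the group, since the group that leaves holds one too. With benzyl kept on the amine nitrogen, acetyl in place of phenylsulfonyl gives a number 0.6 percentage points higher from compound 1 to compound 4 (within the scatter), so the two compounds cannot be ordered and the high number does not need the phenylsulfonyl group. Nothing among the data shown accounts for why the groups differ in this way.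

Still open, from the compounds shown here alone, is whether benzyl is needed on that nitrogen, which a methyl in its place or an amide nitrogen carrying only acetyl and hydrogen would test. Also open, going by these compounds, is how far the acyl side can vary, for instance with a methanesulfonyl or benzoyl group alongside the benzyl, and whether the two high numbers would stay level at a lower dose.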